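Aminothiophene amides on gastric carcinoma cells: removing the acyl group

A few compounds are considered here, and "the series" means these few. Any claim that something is new, unique, unknown or untested is made for them only; others in the source may bear on it.

Measured in a functional assay on MKN-45 cells (Homo sapiens) for inhibition, read by MTT assay; on this read-out lower numbers stand for stronger inhibition and higher numbers for weaker inhibition:
compound 1 `N#Cc1c(N)sc(C(=O)Nc2ccc(Cl)cc2)c1-c1ccccc1`: 420 nM
compound 2 `CCOC(=O)c1c(NC(=O)CC#N)sc(C(=O)Nc2ccc(Cl)cc2)c1-c1ccccc1`: 390 nM
compound 3 `N#CCC(=O)Nc1sc(C(=O)Nc2ccc(Cl)cc2)c(-c2ccccc2)c1C#N`: 590 nM

The three values lie close together. Compound 2 gives the lowest number, yet its gap to compound 1 and to compound 3 stays within the scatter, so no order among the three can be read from these data.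

One structural change is already covered by a measured pair. From compound 3 to compound 1 the change is hydrogen in place of (cyanomethyl)carbonyl on a nitrogen on an aromatic ring and it gave a 1.4-fold lower number from compound 3 to compound 1 (0.15 log units; within the scatter).

Compound 4 `CCOC(=O)c1c(N)sc(C(=O)Nc2ccc(Cl)cc2)c1-c1ccccc1` is not yet measured. Its relation to compound 2 is hydrogen in place of (cyanomethyl)carbonyl on a nitrogen on an aromatic ring, the same change as from compound 3 to compound 1, at a place described in the same words. The two cores differ: ethoxycarbonyl in place of cyano on an aromatic carbon, a difference that gave a 1.5-fold higher number from compound 2 to compound 3 (0.18 log units; within the scatter).

Because a 1.4-fold lower number from compound 3 to compound 1 (0.15 log units; within the scatter) stayed within the scatter, the step from compound 2 to compound 4 is expected to be small as well, estimated at a 1.3-fold lower number from compound 2 to compound 4 (0.11 log units; within the scatter). Compound 4 is therefore expected near 300 nM in this assay, between 150 nM and 600 nM.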

Compound 4, half-maximal inhibitory concentration: 260 nM
Beside the measured number, compound 4's estimate is 1.2-fold (0.06 log units) above it; the measured number falls inside the stated range.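

Removing the (cyanomethyl)carbonyl from the nitrogen on the aromatic ring gives a 1.5-fold lower number from compound 2 to compound 4 (0.18 log units; within the scatter) in this assay, and this step matches the one seen on the core of compound 1: the same change on two cores in this assay, a 1.4-fold lower number (0.15 log units; within the scatter) from compound 3 to compound 1 and a 1.5-fold lower number (0.18 log units; within the scatter) from compound 2 to compound 4, 1.1-fold (0.03 log units) apart, within the scatter of two such steps. Ethoxycarbonyl in place of cyano on an aromatic carbon gives a 1.6-fold lower number from compound 1 to compound 4 (0.21 log units; within the scatter), and this step likewise matches its earlier counterpart: the same change on two cores in this assay, a 1.5-fold higher number (0.18 log units; within the scatter) from compound 2 to compound 3 and a 1.6-fold higher number (0.21 log units; within the scatter) from compound 4 to compound 1, 1.1-fold (0.03 log units) apart, within the scatter of two such steps. Each change therefore carries across these two cores as a step within the scatter, and the two changes show no sign of depending on each other, but neither step is shown to be a real effect, and nothing here extends to any other core.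

The compounds shown leave open whether a longer acyl chain in place of (cyanomethyl)carbonyl, or an alkyl amine at that nitrogen, would move the number beyond the scatter. On these data alone, a carboxylic acid in place of ethoxycarbonyl remains equally open.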